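Moving a Methoxy Group on a Biaryl Lactam

The compounds below may be only part of what the source reports. "The series", "measured", "known", "first", "only" and "open" are said of these compounds alone.

Compound 1, `O=C(c1ccco1)N1CCN(C2CC(=O)N(c3ccc(-c4ccccc4F)cc3)C2)CC1`: 37 nM
Compound 2, `COc1ccccc1-c1cccc(N2CC(N3CCN(c4ncccn4)CC3)CC2=O)c1`: 85 nM

Both compounds were tested in an assay on isolated protein for inhibition of Monoglyceride lipase (Mus musculus), with a stated time of 30 min; on this read-out higher numbers stand for weaker inhibition and lower numbers for stronger inhibition. Compound 1 gives 37 nM and compound 2 gives 85 nM. Of the two numbers, compound 2 has the higher one, and its gap to compound 1 is beyond the usual scatter, so compound 2 is the weaker inhibitor of this pair.

Compound 3, `COc1cccc(-c2cccc(N3CC(N4CCN(c5ncccn5)CC4)CC3=O)c2)c1`, has not yet been measured in this assay. It is built from the same atoms as compound 2, joined differently: 3-methoxyphenyl in place of 2-methoxyphenyl on an aromatic carbon. Among the measured compounds shown here, no measured pair shows what this kind of move does here, so the direction of the step is open; a change no larger than the usual scatter is expected, in either direction. The step from compound 2 to compound 3 is expected to be a 1.1-fold lower number from compound 2 to compound 3 (0.03 log units; within the scatter). Compound 3 is therefore expected to give about 80 nM, within a range from 25 nM to 260 nM.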

Compound 3, half-maximal inhibitory concentration: 39 nM
Beside the measured number, compound 3's estimate is 2.1-fold (0.31 log units) above it; measured number inside the range.
By their numbers in this assay, from the lowest: compounds 1 and 3 (each within the scatter of the next); then compound 2.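

In this assay, among the compounds shown here, this pair gives the first direct reading at this position: there is a 2.2-fold lower number from compound 2 to compound 3 (0.34 log units; beyond the scatter) and the two compounds have the same atoms, joined differently. Where the methoxy group sits on this aromatic ring therefore matters, even though the step is modest, and 3-methoxyphenyl gives the stronger inhibition of the two groups compared here. Nothing available explains the difference, so it stands as an observation without a known cause.

One pair cannot show whether the same move would act similarly on a different scaffold, such as the core of compound 1. Also open, on these data alone, is what a hydroxyl group, an ethoxy group or a nitrile would do in place of the methoxy group on this ring.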